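Benzyl for tert-butyl on the carbamate oxygen

The compounds below may be only part of what the source reports. "The series", "measured", "known", "first", "only" and "open" are said of these compounds alone.

Compound 1 `Cc1cc(C(=O)Nc2c(F)cccc2F)nn1Cc1cc(Cl)ccc1OCc1ccccc1`: 3.7
Compound 2 `Cc1cc(NC(=O)CC2CCCCC2)nn1Cc1cc(Cl)ccc1OCc1ccccc1`: 3.2
Compound 3 `Cc1cc(NC(=O)OC(C)(C)C)nn1Cc1cc(Cl)ccc1OCc1ccccc1`: > 3.7

Of the compounds shown here, three on the shared core have been measured in a physicochemical assay for lipophilicity, at pH 7.4; a lower number here means a more polar compound, a higher number a more lipophilic compound. Compound 1 gives 3.7 and compound 2 gives 3.2, a step of a number 0.50 log units lower from compound 1 to compound 2 (beyond the scatter). For compound 3 the assay reports only a limit, > 3.7, so its exact standing is open (the limit of > 3.7 in this assay, at which 1 of the 3 values shown sits). Against compound 2 this still reads as a number at least 0.50 log units higher from compound 2 to compound 3 (beyond the scatter), while against compound 1 it reads as a number no lower from compound 1 to compound 3 (the limit leaves the size open).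

Compound 4 `Cc1cc(NC(=O)OCc2ccccc2)nn1Cc1cc(Cl)ccc1OCc1ccccc1` is not yet measured. It differs from compound 3 by benzyl in place of tert-butyl on an oxygen next to a carbonyl group. Within the data shown here, none of the measured steps exchanges one alkyl group on the carbamate oxygen for another; the nearest is the step of a number at least 0.50 log units higher from compound 2 to compound 3 (beyond the scatter), which only shows that the tert-butoxy carbamate of compound 3 sits at the limit. With compound 3 already at the limit, compound 4 is expected to remain at or beyond it, and the step is estimated as a step that the limit leaves unreadable from compound 3 to compound 4, most likely reported again only as a limit. The estimate for compound 4 in this assay is 4.2, with a range from 3.7 to 4.8.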

Compound 4, distribution coefficient: 3.1
Estimate against measurement, compound 4: 1.10 log units above; the measured number lies below the stated range.
By their numbers in this assay, from the lowest: compounds 4 and 2 (each within the scatter of the next); then compound 1.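

In this assay, the exchange on the carbamate oxygen can now be read, and benzyl in place of tert-butyl gives a number at least 0.60 log units lower from compound 3 to compound 4 (beyond the scatter). Compound 3 alone had left open whether the carbamate link itself went with the high reading, but compound 4 keeps that link and still reads as a number 0.60 log units lower from compound 1 to compound 4 (beyond the scatter), so at this position the number follows the group on the oxygen and not the carbamate as such, even though benzyl brings more carbon atoms and an aromatic ring. Against the amide of compound 2, the result reads as a number 0.10 log units lower from compound 2 to compound 4 (within the scatter), so benzyloxy and cyclohexylmethyl on this carbonyl carbon cannot be told apart here.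

How far compound 3 really lies from the other compounds stays open: the limit of > 3.7 in this assay, at which 1 of the 4 values shown sits. Nor do the compounds shown say how a smaller group such as methyl or ethyl on the carbamate oxygen would read, or what an amine or a carboxylic acid on the benzyl ring would do to the number.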